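The source may hold more compounds than are shown below. What is called first, only, known or untested is meant among the compounds shown, and "the series" means these compounds.

Values in a functional assay on PC-3 cells (Homo sapiens) for inhibition, read by sulforhodamine B assay; on this read-out higher numbers stand for weaker inhibition of growth and lower numbers for stronger inhibition of growth:
compound 1 `CN(C)c1ccc(-c2ccc(-c3ccc(-c4nc5ccccc5[nH]4)cc3)cc2)cc1` gives 100000 nM
compound 2 `Oc1cccc2[nH]c(-c3ccc(-c4ccc(-c5ccc(C(F)(F)F)cc5)cc4)cc3)nc12` gives 2260 nM

Compound 2 holds the lower of the two numbers, and its gap to compound 1 lies beyond the scatter. Compound 3 `CN(C)c1ccc(-c2ccc(-c3ccc(-c4nc5c(O)cccc5[nH]4)cc3)cc2)cc1` has not yet been measured. Relative to compound 2, it has dimethylamino in place of trifluoromethyl on an aromatic carbon, para to a large group dimethylamino in place of trifluoromethyl on an aromatic carbon in the counted comparison. Within the data shown here, no step between measured compounds tests this change. Among the measured compounds shown here, compound 1, the only measured compound with dimethylamino, gives 100000 nM in this assay, so a higher number, meaning weaker inhibition of growth, is expected, with a moderate step beyond the scatter. The expected change is a 2.7-fold higher number from compound 2 to compound 3 (0.42 log units; beyond the scatter) on this estimate. For compound 3 the estimated value is 6000 nM with an expected range of 1500 nM to 30000 nM for repeat measurements.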

Compound 3, concentration for 50% growth inhibition: 8420 nM
The estimate for compound 3 lay 1.4-fold (0.15 log units) below the measured number; the measured number falls inside the stated range.
By their numbers in this assay, from the lowest: compound 2; then compound 3; then compound 1.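

In this assay, dimethylamino in place of trifluoromethyl on this aromatic carbon, para to a large group, can now be read directly with the hydroxy group held in place: the swap gives a 3.7-fold higher number from compound 2 to compound 3 (0.57 log units; beyond the scatter) and counts as a modest step. Hydroxy in place of hydrogen on an aromatic carbon, read with dimethylamino held in place, gives a 12-fold lower number from compound 1 to compound 3 (1.07 log units; beyond the scatter) and counts as a large step, so the weak number of compound 1 does not carry over to compound 3. Nothing at hand gives a reason for either step.

Open, as far as these compounds go, is whether the hydroxy step keeps its size with trifluoromethyl on the far ring. Also open, from the compounds shown here alone, is how a nitrile or a carboxylic acid on that carbon, or a methoxy group in place of the hydroxy, would read in this assay.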